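This account rests on a few compounds, and the source may have more. Where it says the series, first, only, none or still open, it means among the compounds named here.

Measured compounds:
compound 1, `CN(C)C1=Nc2ccccc2C(CC(=O)NCc2ccc(N)cc2)N1c1ccccc1`: 380 nM
compound 2, `CC(C)(C)OC(=O)NCCCCCNC1=Nc2ccccc2C(CC(=O)NCc2ccccc2)N1c1ccccc1`: 570 nM

In an assay on HEK293 cells for inhibition of Voltage-dependent T-type calcium channel subunit alpha-1G (Homo sapiens), read by patch clamp (on this read-out lower numbers stand for stronger inhibition and higher numbers for weaker inhibition), compound 1 gives 380 nM. In the same assay compound 2 gives 570 nM. The gap between these two numbers is within the scatter of repeated measurements, so neither compound stands apart from the other, and compound 1 is simply one of two closely matched results.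

Compound 3, `CN(C)C1=Nc2ccccc2C(CC(=O)NCc2ccc([N+](=O)[O-])cc2)N1c1ccccc1`, differs from compound 1 in a single place: nitro in place of amino on an aromatic carbon. Among the compounds with values here, no measured pair in this set carries the same change, so there is no direct guide to its size or direction. The step from compound 1 to compound 3 is expected to be a 1.3-fold higher number from compound 1 to compound 3 (0.12 log units; within the scatter), that is, no step beyond the usual scatter in either direction. Compound 3 is therefore estimated at 500 nM, with a range from 150 nM to 1700 nM.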

Compound 3, half-maximal inhibitory concentration: 350 nM
For compound 3 the middle estimate is 1.4-fold (0.15 log units) above the measured one; measured number inside the range.
By their numbers in this assay, from the lowest: compounds 3, 1 and 2 (each within the scatter of the next).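

The exchange of amino for nitro on an aromatic carbon, para to a large group, gives a 1.1-fold lower number from compound 1 to compound 3 (0.04 log units; within the scatter) in this assay. Within the data shown here, this is the first comparison in the set between compounds that differ in one place, and it shows that, with the rest of compound 1 held fixed, this 4-aminobenzyl to 4-nitrobenzyl change leaves the number within the scatter, even though the hydrogen-bond donor of the amino group is gone and a larger group with more oxygen takes its place. The data offer no measured property that would account for this result.

On these data alone, it remains open whether a carboxylic acid, a methoxy group or a plain hydrogen on this same carbon would also stay within the scatter of compound 1. The same single step, from amino to nitro, also remains to be seen on a different side chain.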